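Propyl in place of hydrogen on the phenol oxygen

The compounds below may be only part of what the source reports. "The series", "measured", "known", "first", "only" and "open" are said of these compounds alone.

Measured compounds:
compound 1, `Nc1ncnc2c1nc(NCc1ccc(-c3ccccn3)cc1)n2[C@@H]1O[C@H](CO)[C@@H](O)[C@H]1O`, 1500 nM
compound 2, `Nc1ncnc2c1nc(NCc1ccc(-c3ccccc3)c(O)c1)n2[C@@H]1O[C@H](CO)[C@@H](O)[C@H]1O`, 1200 nM

In an assay on COS-7 cells for inhibition of sodium/nucleoside cotransporter 2 (Homo sapiens), read by scintillation counting (a higher number here means a weaker inhibitor, a lower number a stronger inhibitor), compound 1 gives 1500 nM, and compound 2 gives 1200 nM. Compound 2 holds the lowest of the two numbers, but the gap to compound 1 lies within the scatter, so the two compounds are not separated by these data.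

Compound 3, `CCCOc1cc(CNc2nc3c(N)ncnc3n2[C@@H]2O[C@H](CO)[C@@H](O)[C@H]2O)ccc1-c1ccccc1`, is compound 2 with one change: propyl in place of hydrogen on an oxygen on an aromatic ring. Going by the values given here, no measured pair in this set carries a change of this kind, so there is no step to lean on. Among the compounds with values here, with only two compounds and no comparable step, the expectation is a small move in this assay, with no direction that the data can support; the step from compound 2 to compound 3 is estimated as a 1.2-fold higher number from compound 2 to compound 3 (0.07 log units; within the scatter). For compound 3 the expected value in this assay is 1400 nM, with a range from 450 nM to 4500 nM.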

Compound 3, half-maximal inhibitory concentration: 5200 nM
The estimate for compound 3 lay 3.7-fold (0.57 log units) below the measured number, outside the stated range (above it).
By their numbers in this assay, from the lowest: compounds 2 and 1 (each within the scatter of the next); then compound 3.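

In this assay, going by these compounds alone, propyl in place of hydrogen on the oxygen on the aromatic ring brings a 4.3-fold higher number from compound 2 to compound 3 (0.64 log units; beyond the scatter) and so shows that this position responds to substitution, which the earlier compounds could not show without any step between them. The move is towards a weaker inhibitor, but it is a single step, so it applies to propyl on this oxygen and sets no trend for other groups there. Nothing available here bears on the reason for this step.

Still open, going by these compounds, is whether the change in number tracks chain length, which methoxy, ethoxy or a longer chain such as butoxy on the same oxygen would test. Also open, on these data alone, is whether the oxygen itself is needed, a question that an amine or a fluorine at the same place could address.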